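One added methoxy on compound 3

The compounds below may be only part of what the source reports. "The series", "measured", "known", "first", "only" and "open" are said of these compounds alone.

Compound 1 `COc1cc(NC(=O)/C=C/c2ccccc2C(F)(F)F)cc(OC)c1OC`: > 200000 nM
Compound 2 `COc1ccc(NC(=O)/C=C/c2ccccc2C(F)(F)F)cc1OC`: > 200000 nM
Compound 3 `COc1ccc(/C=C(\C#N)C(=O)Nc2ccccc2OC)cc1`: > 200000 nM

All three entries are limits of an ADME assay on HBZY-1 cells (Rattus norvegicus) for cytotoxicity, read by MTT assay, with a stated time of 2 h (a lower number here means a stronger inhibitor, a higher number a weaker inhibitor), not numbers. Compound 3 stands only at its limit of > 200000 nM. Compound 4 `COc1ccccc1NC(=O)/C(C#N)=C/c1ccc(OC)c(OC)c1` has not yet been measured. It differs from compound 3 by methoxy in place of hydrogen on an aromatic carbon. Among the compounds with values here, the one measured step of this kind, a step that the two limits leave unreadable from compound 1 to compound 2, runs the opposite way and gives no size. Every value shown stands at the limit of > 200000 nM in this assay, at which 3 of the 3 values shown sit, so no step beyond the scatter is expected in this assay, and another limit is the likeliest report. The expected step is a number no higher from compound 3 to compound 4 (the limit leaves the size open). Compound 4 is estimated at 200000 nM, with an expected range of 100000 nM to 400000 nM.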

Compound 4, half-maximal inhibitory concentration: > 200000 nM
Compound 4 gave a limit, no number; the forecaster's own chance of this, stated with the estimate: 85%; the middle value lies on the limit itself.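

Compound 3 and compound 4 both give only a limit, not a number, in this assay, so no step can be read between them. The compounds shown leave open what size, if any, the step for methoxy in place of hydrogen on an aromatic carbon has.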